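Aryl substituent swaps on the dienone series

The compounds below may be only part of what the source reports. "The series", "measured", "known", "first", "only" and "open" are said of these compounds alone.

Measured so far:
compound 1 `CC1=C(/C=C/C(=O)/C=C/c2ccc(Br)cc2)C(C)(C)CCC1` gives 10400 nM in a functional assay on IMR-32 cells (Homo sapiens) for cytotoxicity, read by sulforhodamine B assay, with a stated time of 48 h; a higher number here means a weaker inhibitor, a lower number a stronger inhibitor
compound 2 `COc1ccccc1/C=C/C(=O)/C=C/C1=C(C)CCCC1(C)C` gives 19200 nM
compound 3 `CC1=C(/C=C/C(=O)/C=C/c2ccccc2Br)C(C)(C)CCC1` gives 16300 nM

Compound 1 holds the lowest of the three numbers, but the gaps to compound 3 and to compound 2 both sit within the scatter, so no order can be read among them. Compound 4 `CC1=C(/C=C/C(=O)/C=C/c2ccccc2C)C(C)(C)CCC1` carries 2-methylphenyl in place of 4-bromophenyl on a double-bonded chain carbon bound to a double-bonded chain carbon. Among the compounds with values here, two measured steps bear on it: a 1.6-fold higher number from compound 1 to compound 3 (0.20 log units; within the scatter), and a 1.2-fold lower number from compound 2 to compound 3 (0.07 log units; within the scatter). Neither step exchanges bromine for methyl on a 2-substituted ring, so that change stands untested, but every aryl change seen so far lies within the scatter. For compound 4 no step beyond the scatter is expected in this assay, meaning a 1.3-fold higher number from compound 1 to compound 4 (0.10 log units; within the scatter). Compound 4 is therefore estimated at 13000 nM, between 6000 nM and 28000 nM.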

Compound 4, half-maximal inhibitory concentration: 63200 nM
The estimate for compound 4 lay 4.9-fold (0.69 log units) below the measured number; the measured number lies above the stated range.
By their numbers in this assay, from the lowest: compounds 1, 3 and 2 (each within the scatter of the next); then compound 4.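

In this assay, within the data shown here, 2-methylphenyl is the first aryl change at this place to go beyond the scatter, with a 6.1-fold higher number from compound 1 to compound 4 (0.78 log units; beyond the scatter), a 3.9-fold higher number from compound 3 to compound 4 (0.59 log units; beyond the scatter) and a 3.3-fold higher number from compound 2 to compound 4 (0.52 log units; beyond the scatter). On this aromatic carbon, bromo and methoxy stay within the scatter of each other, while methyl stands apart from both, so the position does not accept every substituent alike. Nothing available accounts for this separation. From the compounds shown here alone, whether an amine or a carboxylic acid on the same aromatic carbon would group with methyl or with bromo and methoxy stays open.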